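Chloro Substitution on the Aryl Core of Compound 1

A few compounds are considered here, and "the series" means these few. Any claim that something is new, unique, unknown or untested is made for them only; others in the source may bear on it.

Compound 1 `C[C@@H]1CN(c2cccc(NS(=O)(=O)c3ccc(-c4ccccn4)s3)c2)C[C@H](C)N1` sits second highest among the three numbers measured in a functional assay for agonist activity at growth hormone secretagogue receptor type 1 (Homo sapiens), read by FLIPR (a higher number here means that more compound is needed for the effect, a lower number that less compound is needed), where compound 1 gives 39.8 nM. Compound 3 `COc1ccc(N2C[C@@H](C)N[C@@H](C)C2)cc1NS(=O)(=O)c1ccc(-c2ccccn2)s1` lies nearest, as compound 3 gives 10 nM, a change of a 4.0-fold lower number from compound 1 to compound 3 (0.60 log units; beyond the scatter). Compound 2 `C[C@@H]1CN(c2cc(NS(=O)(=O)c3ccc(-c4ccccn4)s3)ccc2C#N)C[C@H](C)N1` lies furthest, as compound 2 gives 631 nM, a change of a 16-fold higher number from compound 1 to compound 2 (1.20 log units; beyond the scatter). Compound 4 `C[C@@H]1CN(c2ccc(Cl)c(NS(=O)(=O)c3ccc(-c4ccccn4)s3)c2)C[C@H](C)N1` differs from compound 1 by chloro in place of hydrogen on an aromatic carbon, a single chlorine placed on an aromatic carbon of the six-membered carbon-only ring, ortho to a large group and para to the 3,5-dimethylpiperazin-1-yl group. The two measured steps point in opposite directions: the methoxy addition gave the modest step of a 4.0-fold lower number from compound 1 to compound 3 (0.60 log units; beyond the scatter), while the cyano addition gave the large step of a 16-fold higher number from compound 1 to compound 2 (1.20 log units; beyond the scatter). A single halogen is closer in kind to the methoxy case, so a modest step downward is expected for compound 4, of about a 2.0-fold lower number from compound 1 to compound 4 (0.30 log units; within the scatter). Compound 4 is therefore estimated to give 20 nM in this assay, within a range from 6 nM to 63 nM.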

Compound 4, half-maximal effective concentration: 39.8 nM
Compound 4: the middle estimate sits 2.0-fold (0.30 log units) below what was measured; the measured number falls inside the stated range.
By their numbers in this assay, from the lowest: compound 3; then compounds 1 and 4 (each within the scatter of the next); then compound 2.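

On this aromatic carbon, ortho to a large group and para to the 3,5-dimethylpiperazin-1-yl group, a substituent does not necessarily move the number in this assay, since chloro in place of hydrogen gives no change at the digits printed from compound 1 to compound 4 (within the scatter) at this place. Methoxy sits on the same carbon, and chloro in its place gives a 4.0-fold higher number from compound 3 to compound 4 (0.60 log units; beyond the scatter), so the lower number seen with methoxy does not extend to every group on this carbon. No measurement shown here accounts for the difference between these two groups.

The compounds shown leave open whether a fluorine, a hydroxyl, an ethoxy or an amine on this carbon would read like methoxy or like chloro. They also leave open how chloro would read on the carbon that carries the nitrile in compound 2.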